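The compounds below may be only part of what the source reports. "The series", "measured", "known", "first", "only" and "open" are said of these compounds alone.

Of the compounds shown here, three that share one core have been measured in a physicochemical assay for acid dissociation. Compound 1 `CCC(CC)c1ccc2c(NCCCNCc3cccc(OC)c3O)ccnc2c1` gives 9.47 in this assay. Compound 2 `COc1ccc(-c2ccc3c(NCCCNCc4cc(F)ccc4OC)ccnc3c2)cc1` gives 9.47 in this assay. Compound 3 `COc1cccc(CNCCCNc2ccnc3cc(-c4ccc(F)cc4)ccc23)c1O` gives 9.47 in this assay, so compound 3 stands level with compound 1 and with compound 2 at the digits shown, and none of the three can be set apart from the others on these numbers.

One measured step connects two of them directly: no change at the digits printed from compound 1 to compound 3 (within the scatter). That step swaps a group on the core far from the site now in question and leaves the proton's readiness to dissociate unchanged.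

Compound 4 `COc1ccc(-c2ccc3c(NCCCNCc4cccc(OC)c4O)ccnc3c2)cc1` is not yet measured. Compared with compound 3 it carries methoxy in place of fluoro on an aromatic carbon. Going by the values given here, no measured step touches this same position, so the only guidance is that the one measured step, from compound 1 to compound 3, and the level values of compounds 1, 2 and 3 all point to a proton whose dissociation is insensitive to the groups varied so far. On that basis the step from compound 3 to compound 4 is expected to be no change at the digits printed from compound 3 to compound 4 (within the scatter), nothing beyond the scatter. Compound 4 is therefore estimated at 9.47, within 9.17 to 9.77.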

Compound 4, acid dissociation constant: 9.47
Estimate against measurement, compound 4: no gap at the digits printed, and the stated range covers the measured number.
By their numbers in this assay, from the lowest: compounds 1, 2, 3 and 4 (each within the scatter of the next).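

In this assay, the change from 4-fluorophenyl to 4-methoxyphenyl gives no change at the digits printed from compound 3 to compound 4 (within the scatter) and so adds a new kind of swap at this position to the list of changes that leave the reading flat. Going by these compounds alone, compound 4 also allows a comparison that no earlier pair offered: 2-hydroxy-3-methoxyphenyl in place of 5-fluoro-2-methoxyphenyl on the saturated chain carbon gives no change at the digits printed from compound 2 to compound 4 (within the scatter) even though this swap lies away from the position just discussed, while 4-methoxyphenyl in place of pentan-3-yl gives no change at the digits printed from compound 1 to compound 4 (within the scatter) and agrees with the earlier swap of that group. No compound among these four goes against this flat picture, and no supporting measurement is available to account for it.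

Going by these compounds, what remains open is whether the same flat reading would hold for a group of a different kind, such as an amine or a carboxylic acid in place of the methoxy on this phenyl ring. A longer chain between the two nitrogens of the shared core is also untested by the compounds shown here.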